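A few compounds are considered here, and "the series" means these few. Any claim that something is new, unique, unknown or untested is made for them only; others in the source may bear on it.

Compound 2 `N#Cc1ccc(NC(=S)N/N=C/c2ccc3ccccc3n2)cc1` carries a 4-cyanophenyl group on a thiosemicarbazone attached to the shared core. In a functional assay on HL-60 cells (Homo sapiens) for antiproliferative activity, read by sulforhodamine B assay, with a stated time of 72 h (on this read-out lower numbers stand for stronger inhibition and higher numbers for weaker inhibition), compound 2 gives 4660 nM, the highest of the two numbers reported here; its nearest neighbour, compound 3 `CN(C)C(=S)N/N=C/c1cnc2ccccc2n1`, gives 90 nM, a gap well beyond the scatter. Compound 1 `COc1ccc(C)cc1NC(=S)N/N=C/c1ccc2ccccc2n1` reaches only a limit, > 100000 nM, in this assay (the limit of > 100000 nM in this assay, at which 1 of the 3 values shown sits). Compound 4 `Fc1ccc(NC(=S)N/N=C/c2ccc3ccccc3n2)cc1` has not yet been measured; it differs from compound 2 in a single place: fluoro in place of cyano on an aromatic carbon. For the measured compounds named here, no measured pair shows this kind of change, so the size of its effect in this assay is uncertain; a modest loss, barely beyond the scatter, is expected, a 2.6-fold higher number from compound 2 to compound 4 (0.41 log units; beyond the scatter). Compound 4 is therefore estimated at 12000 nM, likely between 2500 nM and 60000 nM.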

Compound 4, half-maximal inhibitory concentration: 17000 nM
Compound 4: middle estimate off by 1.4-fold (0.15 log units), on the low side, within the range that was stated.
By their numbers in this assay, from the lowest: compound 3; then compound 2; then compound 4. At a limit, above all of these: compound 1.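

Fluoro in place of cyano on an aromatic carbon, para to a large group, brings a 3.6-fold higher number from compound 2 to compound 4 (0.56 log units; beyond the scatter) in this assay, the only measured step at this position. The position therefore responds to this change, but modestly, and compound 4 still gives a number rather than a limit. Nothing shown here accounts for the size of this step.

The compounds shown leave open how an amine or a carboxylic acid at this position would compare. They also leave open whether the same change would have a similar effect on a different core.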